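Trifluoromethyl analogue of an ethyl pyrimidinone thioether: cytotoxicity outlook

The source may hold more compounds than are shown below. What is called first, only, known or untested is meant among the compounds shown, and "the series" means these compounds.

Compound 1: `COc1ccc(C(=O)CSc2nc(Cc3ccc(Br)cc3)c(C)c(=O)[nH]2)cc1`, > 272000 nM
Compound 2: `COc1ccc(C(=O)CSc2nc(Cc3cc(C(F)(F)F)cc(C(F)(F)F)c3)c(C)c(=O)[nH]2)cc1`, > 242000 nM
Compound 3: `CCc1c(Cc2ccc(Br)cc2)nc(SCC(=O)c2ccc(OC)cc2)[nH]c1=O`, > 264000 nM

Three thioether pyrimidinones were examined in an ADME assay on MT4 cells (Homo sapiens) for cytotoxicity; on this read-out lower numbers stand for higher toxicity in this test and higher numbers for lower toxicity in this test. Compound 1 `COc1ccc(C(=O)CSc2nc(Cc3ccc(Br)cc3)c(C)c(=O)[nH]2)cc1` reached only a limit of the assay, > 272000 nM. Compound 2 `COc1ccc(C(=O)CSc2nc(Cc3cc(C(F)(F)F)cc(C(F)(F)F)c3)c(C)c(=O)[nH]2)cc1` likewise gave only a limit, > 242000 nM. Compound 3 `CCc1c(Cc2ccc(Br)cc2)nc(SCC(=O)c2ccc(OC)cc2)[nH]c1=O` also stopped at a limit, > 264000 nM.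

Compound 3 differs from compound 1 by methyl in place of hydrogen on a saturated chain carbon bound to an aromatic carbon. The step that the two limits leave unreadable from compound 1 to compound 3 cannot be read, because the limit of > 272000 nM in this assay, at which 1 of the 3 values shown sits, and the limit of > 264000 nM in this assay, at which 1 of the 3 values shown sits, are both limits and no number lies on either side. How the core of compound 2 differs from that of compound 1 is not broken down here.

Compound 4 `CCc1c(Cc2cc(C(F)(F)F)cc(C(F)(F)F)c2)nc(SCC(=O)c2ccc(OC)cc2)[nH]c1=O` is not yet measured; it differs from compound 2 by methyl in place of hydrogen on a saturated chain carbon bound to an aromatic carbon, the same change as from compound 1 to compound 3. Since that earlier change left both compounds at a limit, compound 4 is expected to behave alike, with an estimated step that the limit leaves unreadable from compound 2 to compound 4. The estimate for compound 4 in this assay is 300000 nM, between 150000 nM and 600000 nM.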

Compound 4, half-maximal cytotoxic concentration: > 236000 nM
Compound 4: a limit, no number; the forecaster's own chance of this, stated with the estimate: 80%; the middle value is on the limit's open side.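

Compound 4 gave only a limit, > 236000 nM. Compound 2 also stands at a limit, > 242000 nM, so no step can be read between compound 2 and compound 4. The compounds shown leave open whether methyl in place of hydrogen on a saturated chain carbon bound to an aromatic carbon shifts the cytotoxicity read-out at all.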